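The source may hold more compounds than are shown below. What is called first, only, known or untested is meant among the compounds shown, and "the series" means these compounds.

Of the compounds shown here, three sharing one core have been tested in an ADME assay on HFF cells (Homo sapiens) for cytotoxicity, with a stated time of 8 days; a higher number here means that more compound is tolerated, a lower number that less compound is tolerated. Compound 1 `CN(C)c1nc(N)nc2c1ncn2/C=C1/CC1(CO)CO` carries a dimethylamino group on the core. In this assay compound 1 gives > 300000 nM, which is a limit of the assay rather than a number. Compound 2 `Nc1nc(NCc2ccccc2)c2ncn(/C=C3/CC3(CO)CO)c2n1` carries a benzylamino group in that place. In this assay compound 2 gives > 300000 nM, again a limit. Compound 3 `CC(C)CNc1nc(N)nc2c1ncn2/C=C1/CC1(CO)CO` carries an isobutylamino group. In this assay compound 3 gives > 300000 nM, also a limit. Because of the limit of > 300000 nM in this assay, at which 3 of the 3 values shown sit, none of the steps between these three can be read: a step that the two limits leave unreadable from compound 1 to compound 2, a step that the two limits leave unreadable from compound 1 to compound 3 and a step that the two limits leave unreadable from compound 2 to compound 3. Compound 2 thus stands at the limit, exactly where the other two values shown also sit.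

Compound 4 `CCCCCCOc1nc(N)nc2c1ncn2/C=C1/CC1(CO)CO` differs from compound 2 in one place: hexyloxy in place of benzylamino on an aromatic carbon. The measured steps that bear on this change are all unreadable at the limit, so no step beyond the scatter is expected in this assay, in either direction. Compound 4 is therefore expected to give 300000 nM, within a range from 100000 nM to 900000 nM, corresponding to an expected a number no higher from compound 2 to compound 4 (the limit leaves the size open).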

Compound 4, half-maximal cytotoxic concentration: > 200000 nM
Compound 4 was reported as a limit; the forecaster's own chance of this, stated with the estimate: 85%; the middle value does not contradict the limit.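

In this assay compound 4 gives > 200000 nM, which is a limit of the assay and not a number. Its steps to compound 1, compound 2 and compound 3 cannot be read. The compounds shown leave open whether any of these groups on the aromatic carbon changes how much compound the cells tolerate.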